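Changing the aryl group on the sulfonyl sulfur

The source may report more compounds than this note shows. Statements on the series, on what has been measured and on what is new or still open speak of the compounds shown alone.

Compound 3 `CC(=O)Nc1ccc(S(=O)(=O)Nc2cccc(-c3nc(-c4ccc(NC(=O)c5cccnc5)cc4Cl)no3)c2)cc1C` carries a 4-acetamido-3-methylphenyl group on a sulfonyl sulfur. In a functional assay on MDA-MB-231 cells (Homo sapiens) for antiproliferative activity, read by MTT assay, with a stated time of 72 h (a lower number here means a stronger inhibitor, a higher number a weaker inhibitor), compound 3 gives > 10000 nM, which is a limit of the assay rather than a number. Compound 1 `O=C(Nc1ccc(-c2noc(-c3cccc(NS(=O)(=O)c4cccc(Cl)c4)c3)n2)c(Cl)c1)c1cccnc1` gives > 10000 nM in this assay, again a limit. Compound 2 `NS(=O)(=O)c1ccc(S(=O)(=O)Nc2cccc(-c3nc(-c4ccc(NC(=O)c5cccnc5)cc4Cl)no3)c2)cc1` gives > 10000 nM in this assay, a limit as well. Because (the limit of > 10000 nM in this assay, at which 3 of the 3 values shown sit), the steps a step that the two limits leave unreadable from compound 1 to compound 2, a step that the two limits leave unreadable from compound 1 to compound 3 and a step that the two limits leave unreadable from compound 2 to compound 3 cannot be read in size or direction.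

Compound 4 `NC(=O)Nc1ccc(S(=O)(=O)Nc2cccc(-c3nc(-c4ccc(NC(=O)c5cccnc5)cc4Cl)no3)c2)cc1` differs from compound 3 in one place: 4-ureidophenyl in place of 4-acetamido-3-methylphenyl on a sulfonyl sulfur. The three measured steps show that swapping the aryl group on the sulfonyl sulfur has so far left every compound at the limit, so the step that the limit leaves unreadable from compound 3 to compound 4 is expected to stay within what the limit allows, with no readable change. Compound 4 is therefore estimated to give 15000 nM in this assay, within a range of 4000 nM to 60000 nM, most likely reported as a limit.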

Compound 4, half-maximal inhibitory concentration: 2800 nM
The estimate for compound 4 lay 5.4-fold (0.73 log units) above the measured number, outside the stated range (below it).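

In this assay, the aryl group on the sulfonyl sulfur now proves able to change the result, with 4-ureidophenyl giving an at least 3.5-fold lower number from compound 3 to compound 4 (0.55 log units; beyond the scatter), an at least 3.5-fold lower number from compound 2 to compound 4 (0.55 log units; beyond the scatter) and an at least 3.5-fold lower number from compound 1 to compound 4 (0.55 log units; beyond the scatter). Compound 4 is the only one of the four with a measured number, so the gain belongs to this one group and does not extend to the 3-chlorophenyl, 4-sulfamoylphenyl or 4-acetamido-3-methylphenyl groups of compounds 1, 2 and 3. Each of these steps gives only a minimum size, because the other compound in each pair has no exact value: the limit of > 10000 nM in this assay, at which 3 of the 4 values shown sit.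

The compounds shown leave open whether the full ureido group is needed or a simpler group on the phenyl ring, such as a plain amine or a carboxylic acid, would serve as well. They also leave open whether a longer chain on the ureido group would lower the number further.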